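The source may hold more compounds than are shown below. What is called first, only, known or untested is meant among the compounds shown, and "the series" means these compounds.

In a functional assay on A549 cells (Homo sapiens) for cytotoxicity, read by MTT assay, with a stated time of 72 h (on this read-out higher numbers stand for weaker inhibition and lower numbers for stronger inhibition), compound 1 `Cc1ccc(NC(=O)CN2CCN(c3nnc(Cc4ccncc4)c4ccccc34)CC2)c(C)c1` gives 45000 nM, compound 2 `O=C(CN1CCN(c2nnc(Cc3ccncc3)c3ccccc23)CC1)Nc1cccc(Br)c1` gives 1530 nM and compound 3 `O=C(CN1CCN(c2nnc(Cc3ccncc3)c3ccccc23)CC1)Nc1ccc(Br)cc1` gives 2710 nM. That places the last of these close to its nearest neighbour, a 1.8-fold higher number from compound 2 to compound 3 (0.25 log units; within the scatter), and far from its furthest, a 17-fold lower number from compound 1 to compound 3 (1.22 log units; beyond the scatter). Next is compound 4 `O=C(CN1CCN(c2nnc(Cc3ccncc3)c3ccccc23)CC1)Nc1cccc(F)c1`, with 3-fluorophenyl in place of 4-bromophenyl on an amide-type nitrogen. The large step of a 29-fold lower number from compound 1 to compound 2 (1.47 log units; beyond the scatter) concerns 2,4-dimethylphenyl, which is not involved here. For the measured compounds named here, the bromine shift stays within the scatter, and no fluorine-bearing compound has been measured. No step beyond the scatter is therefore expected in this assay, and the estimate is a 1.3-fold higher number from compound 3 to compound 4 (0.11 log units; within the scatter). For compound 4 the expected value is 3500 nM, with an estimated range of 1200 nM to 12000 nM.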

Compound 4, half-maximal inhibitory concentration: 4600 nM
Compound 4: the middle estimate sits 1.3-fold (0.12 log units) below what was measured, and the stated range covers the measured number.
By their numbers in this assay, from the lowest: compounds 2, 3 and 4 (each within the scatter of the next, the first and the last beyond it); then compound 1.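

In this assay, for the compounds shown here, fluoro in place of bromo on an aromatic carbon gives the first halogen exchange at one ring place, a modest step beyond the scatter (a 3.0-fold higher number from compound 2 to compound 4 (0.48 log units; beyond the scatter)), while the comparison with 4-bromophenyl stays within it (a 1.7-fold higher number from compound 3 to compound 4 (0.23 log units; within the scatter)). Like both bromophenyl groups, 3-fluorophenyl on the amide-type nitrogen gives a lower number than 2,4-dimethylphenyl (a 9.8-fold lower number from compound 1 to compound 4 (0.99 log units; beyond the scatter)). No measurement at hand accounts for the difference between fluoro and bromo. Still open, on these data alone, is how 4-fluorophenyl, 3-chlorophenyl or 3-methoxyphenyl would read at this place.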